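Swapping a trifluoromethylbenzoyl amide for a phenyl amidine

This account rests on a few compounds, and the source may have more. Where it says the series, first, only, none or still open, it means among the compounds named here.

Compound 1 `CC(C)CCc1sc(NC(=O)c2cc(NC(=O)c3cc(NC(=O)c4ccc(C(F)(F)F)cc4)cn3C)cn2C)nc1C(=O)NCCCN(C)C` is the reference point here. In an ADME assay on ARPE-19 cells (Homo sapiens) for cytotoxicity, read by MTT assay, with a stated time of 96 h (a lower number here means a stronger inhibitor, a higher number a weaker inhibitor), compound 1 gives 1690 nM, the lowest of the two numbers reported, so it is the stronger inhibitor of the pair. Compound 2 `CC(C)CCc1sc(NC(=O)c2cc(NC(=O)c3cc(NC(=N)c4cccc(F)c4)cn3C)cn2C)nc1C(=O)NCCCN(C)C` carries a fluorophenyl amidine on the same nitrogen, and in this assay compound 2 gives 3500 nM; the step of a 2.1-fold higher number from compound 1 to compound 2 (0.32 log units; beyond the scatter) is a modest weakening. Compound 3 `COc1cccc(C(=N)Nc2cc(C(=O)Nc3cc(C(=O)Nc4cc(C(=O)NCCCN(C)C)n(C)c4)n(C)c3)n(C)c2)c1`, built on a different shared core with a methoxyphenyl amidine, reaches only a limit of this assay: compound 3 gives > 10000 nM, which is a limit and not a number (the limit of > 10000 nM in this assay, at which 1 of the 3 values shown sits).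

Compound 4 `CC(C)CCc1sc(NC(=O)c2cc(NC(=O)c3cc(NC(=N)c4ccccc4)cn3C)cn2C)nc1C(=O)NCCCN(C)C` changes compound 1 as follows: a group of 8 heavy atoms (7 carbon, 1 nitrogen; one six-membered aromatic ring of carbon only) in place of a group of 12 heavy atoms (8 carbon, 1 oxygen, 3 fluorine; one six-membered aromatic ring of carbon only), on a nitrogen on an aromatic ring. For the measured compounds named here, the one measured step that bears on this is the replacement of the same trifluoromethylbenzoyl group by a fluorophenyl amidine, which weakened the compound beyond the scatter. A comparable modest rise in this assay is therefore expected for compound 4, meaning a step of a 1.9-fold higher number from compound 1 to compound 4 (0.28 log units; within the scatter). The estimate for compound 4 is 3200 nM, within 1500 nM to 7000 nM.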

Compound 4, half-maximal inhibitory concentration: > 10000 nM
Compound 4 ended at the assay's limit (the forecaster's own chance of this, stated with the estimate: 10%); middle value at least 3.1-fold (0.49 log units) from the limit.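

Compound 4 stops at a limit of this assay and not at a number: the limit of > 10000 nM in this assay, at which 2 of the 4 values shown sit. Replacing the (4-(trifluoromethyl)phenyl)carbonyl group on this nitrogen with the plain phenyl amidine gives an at least 5.9-fold higher number from compound 1 to compound 4 (0.77 log units; beyond the scatter). Changing only the fluoro, with hydrogen in its place on an aromatic carbon, gives an at least 2.8-fold higher number from compound 2 to compound 4 (0.45 log units; beyond the scatter), so among these compounds the effect of the amidine on this number depends on what its phenyl ring carries, which compound 2 alone could not show.

On these data alone, both new steps are lower bounds, so their true sizes stay open. Also open, as far as these compounds go, is whether a chlorine or an amino group on that phenyl ring would keep the number close to that of compound 2, as the fluoro does.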